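From furan-3-yl to 1-benzofuran-2-yl on a shared core

The source may report more compounds than this note shows. Statements on the series, on what has been measured and on what is new or still open speak of the compounds shown alone.

In a functional assay on HL-60 cells (Homo sapiens) for antiproliferative activity, read by XTT assay, with a stated time of 72 h (a lower number here means a stronger inhibitor, a higher number a weaker inhibitor), compound 3 (`Cc1ncnc2c1c(-c1ccoc1)cn2[C@@H]1O[C@H](CO)[C@@H](O)[C@H]1O`) gives > 15000 nM as a limit of the assay, not as a number. Compound 4 (`Cc1ncnc2c1c(-c1cc3ccccc3o1)cn2[C@@H]1O[C@H](CO)[C@@H](O)[C@H]1O`) differs from it in one place, with 1-benzofuran-2-yl in place of furan-3-yl on an aromatic carbon. Within the data shown here, no measured step makes this exchange directly. The nearest evidence comes from compound 1 (`CNc1ncnc2c1c(-c1cc3ccccc3o1)cn2[C@@H]1O[C@H](CO)[C@@H](O)[C@H]1O`) and compound 2 (`CN(C)c1ncnc2c1c(-c1cc3ccccc3o1)cn2[C@@H]1O[C@H](CO)[C@@H](O)[C@H]1O`), which both carry 1-benzofuran-2-yl but differ from compound 4 elsewhere on the core. Compound 1 gives 8950 nM as a measured number. Compound 2 gives > 20000 nM as a limit of the assay. Among the measured compounds shown here, the only measured step (an at least 2.2-fold higher number from compound 1 to compound 2 (0.34 log units; beyond the scatter)) concerns another place on the core, so it bears on this exchange only loosely. For the measured compounds named here, with compound 1 at 8950 nM as the sole measured number, a modest move towards a lower number is expected. The result for compound 4 could still be reported as a limit. The expected step is an at least 1.6-fold lower number from compound 3 to compound 4 (0.22 log units; that floor lies within the scatter) by this estimate. In this assay the expected value for compound 4 is 9000 nM with 3000 nM to 20000 nM as the estimated range.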

Compound 4, half-maximal inhibitory concentration: > 20000 nM
Compound 4: a limit, no number; the forecaster's own chance of this, stated with the estimate: 40%; middle value at least 2.2-fold (0.34 log units) from the limit.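

Compound 4 is reported only as a limit, not a number: the limit of > 20000 nM in this assay, at which 2 of the 4 values shown sit.

Its steps from compound 3 and from compound 2 cannot be read, so placing 1-benzofuran-2-yl on this aromatic carbon shows no measurable gain or loss against furan-3-yl. Among these compounds, the one readable step, an at least 2.2-fold higher number from compound 1 to compound 4 (0.34 log units; beyond the scatter), concerns the other place on the core and, together with an at least 2.2-fold higher number from compound 1 to compound 2 (0.34 log units; beyond the scatter), leaves compound 1, with its methylamino group, as the only one of the three 1-benzofuran-2-yl compounds to give a measured number in this assay.

Among the compounds shown here, the effect of exchanging furan-3-yl for 1-benzofuran-2-yl therefore remains open, with no pair of measured numbers to compare. Also open, from the compounds shown here alone, is how furan-3-yl would read alongside methylamino, or how either ring would read with an unsubstituted amino group on that aromatic carbon.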